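A few compounds are considered here, and "the series" means these few. Any claim that something is new, unique, unknown or untested is made for them only; others in the source may bear on it.

In a functional assay on HT-29 cells (Homo sapiens) for antiproliferative activity, read by MTT assay, with a stated time of 72 h (on this read-out lower numbers stand for stronger inhibition and higher numbers for weaker inhibition), compound 3 `C=CC(=O)N(CC(=O)OCC)c1nc(-c2ccccc2)cs1` gives 19000 nM. Compound 2 `C=CC(=O)Nc1nc(-c2ccccc2Cl)cs1` gives 10200 nM, and these two values lie within the scatter of each other. Compound 1 `C=CC(=O)Nc1cnn(Cc2ccccc2)c1` gives > 30000 nM, which is a limit of the assay and not a number.

The next compound, compound 4 `C=CC(=O)N(CC(=O)N1CCOCC1)c1nc(-c2ccccc2)cs1`, departs from compound 3 in one place: morpholin-4-yl in place of ethoxy on a carbonyl carbon. Morpholin-4-yl stands in place of ethoxy on a carbonyl carbon, so that ethoxycarbonyl becomes (morpholin-4-yl)carbonyl. Going by the values given here, no step between measured compounds in this set shows what such a change does in this assay, so the expectation starts from the value of compound 3 at 19000 nM and assumes no shift in either direction. The expected change, a 1.1-fold higher number from compound 3 to compound 4 (0.02 log units; within the scatter), is estimated to stay within the scatter. In this assay the estimate for compound 4 is 20000 nM, with an expected range from 8000 nM to 45000 nM.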

Compound 4, half-maximal inhibitory concentration: 13300 nM
For compound 4 the middle estimate is 1.5-fold (0.18 log units) above the measured one, within the range that was stated.
By their numbers in this assay, from the lowest: compounds 2, 4 and 3 (each within the scatter of the next). At a limit, above all of these: compound 1.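

In this assay, going by these compounds alone, the exchange of ethoxy for morpholin-4-yl on a carbonyl carbon gives the first step that can be read at this position: a 1.4-fold lower number from compound 3 to compound 4 (0.15 log units; within the scatter). The position, on a carbonyl carbon whose other neighbour is a saturated chain carbon, thus carries a group of 6 heavy atoms with a six-membered non-aromatic ring in place of one of 3 heavy atoms with no ring, and the read-out does not move beyond the scatter. The whole series also sits high in the range of this read-out: the limit of > 30000 nM in this assay, at which 1 of the 4 values shown sits.

As far as these compounds go, what a carboxylic acid, a simple amine or a longer chain would do on the same carbonyl carbon stays open. The compounds shown also leave open whether any group in this place can move the number beyond the scatter.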